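The source may hold more compounds than are shown below. What is called first, only, known or untested is meant among the compounds shown, and "the series" means these compounds.

Three compounds were tested in a functional assay on HepG2 cells (Homo sapiens) for cytotoxicity, read by MTT assay, with a stated time of 48 h; a lower number here means a stronger inhibitor, a higher number a weaker inhibitor. Compound 1 `COc1cc(/C=C/C(=O)/C=C/c2nc3cc(C)ccc3n2C)ccc1O` gives 4200 nM. Compound 2 `COc1ccc2c(c1)nc(/C=C/C(=O)/C=C/c1ccc(O)c(OC)c1)n2C` carries methoxy in place of methyl on an aromatic carbon and gives 3800 nM, so the change gave a 1.1-fold lower number from compound 1 to compound 2 (0.04 log units; within the scatter). Compound 3 `COc1ccc(/C=C/C(=O)/C=C/c2nc3cc(C)ccc3n2C)cc1O` has the same atoms as compound 1 joined differently; the difference between the two cores is not broken down here. In this assay compound 3 gives 3300 nM. Compound 4 `COc1ccc2c(c1)nc(/C=C/C(=O)/C=C/c1ccc(OC)c(O)c1)n2C` has not yet been measured; it differs from compound 3 by methoxy in place of methyl on an aromatic carbon, the same change as from compound 1 to compound 2, at the same place. Because the earlier step was a 1.1-fold lower number from compound 1 to compound 2 (0.04 log units; within the scatter), a similar step a 1.1-fold lower number from compound 3 to compound 4 (0.04 log units; within the scatter) is expected. Compound 4 is estimated to give 3000 nM, likely between 1500 nM and 6000 nM.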

Compound 4, half-maximal inhibitory concentration: 4200 nM
Compound 4: the middle estimate sits 1.4-fold (0.15 log units) below what was measured, and the stated range covers the measured number.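

In this assay, methoxy in place of methyl on an aromatic carbon gives a 1.3-fold higher number from compound 3 to compound 4 (0.10 log units; within the scatter), and moving from 4-hydroxy-3-methoxyphenyl to 3-hydroxy-4-methoxyphenyl gives a 1.1-fold higher number from compound 2 to compound 4 (0.04 log units; within the scatter). Set side by side, the methyl-to-methoxy change shows no difference between the two cores that can be told from scatter: the same change on two cores in this assay, a 1.1-fold lower number (0.04 log units; within the scatter) from compound 1 to compound 2 and a 1.3-fold higher number (0.10 log units; within the scatter) from compound 3 to compound 4, 1.4-fold (0.15 log units) apart, within the scatter of two such steps. Among these compounds, this shows that the change left the number within the scatter on both cores, but with steps this small and only two cores, it does not establish a rule for carrying the change to other cores.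

The compounds shown leave open whether a different group on that aromatic carbon, such as an amine or a carboxylic acid, would give a step beyond the scatter.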